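A few compounds are considered here, and "the series" means these few. Any claim that something is new, unique, unknown or untested is made for them only; others in the source may bear on it.

Measured in a functional assay on MDA-MB-231 cells (Homo sapiens) for antiproliferative activity, with a stated time of 72 h; on this read-out lower numbers stand for an effect already at smaller amounts and higher numbers for an effect only at larger amounts of compound:
- Compound 1 `O=C(O)c1ccc(N(Cc2ccc(C3CCCCC3)cc2)C(=O)[C@H]2CCN2S(=O)(=O)c2c(F)c(F)c(F)c(F)c2F)c(F)c1`: > 10000 nM (a limit of the assay, not a number)
- Compound 2 `O=C(NO)c1ccc(N(Cc2ccc(C3CCCC3)cc2)C(=O)[C@H]2CCN2S(=O)(=O)c2c(F)c(F)c(F)c(F)c2F)cc1`: 3100 nM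
- Compound 3 `CONC(=O)c1ccc(N(Cc2ccc(C3CCCCC3)cn2)C(=O)[C@H]2CCN2S(=O)(=O)c2c(F)c(F)c(F)c(F)c2F)c(F)c1`: "not determined" (no result reported)

Compound 3 thus has no number in this assay and no place on the scale that compound 1 and compound 2 define. Compound 4 `Cn1ccc2cc(N(Cc3ccc(C4CCCCC4)cn3)C(=O)[C@H]3CCN3S(=O)(=O)c3c(F)c(F)c(F)c(F)c3F)ccc2c1=O` has not yet been measured. The change a group of 12 heavy atoms (10 carbon, 1 nitrogen, 1 oxygen; one six-membered aromatic ring of carbon only, one six-membered aromatic ring with 1 hetero atom) in place of a group of 12 heavy atoms (8 carbon, 1 nitrogen, 2 oxygen, 1 fluorine; one six-membered aromatic ring of carbon only), on an amide-type nitrogen removes the 2-fluoro-4-(methoxycarbamoyl)phenyl group and puts a group with two six-membered aromatic rings, one holding a hetero atom, on the same amide-type nitrogen. Among the compounds with values here, no step from a number can be stated, so compound 4 is expected to fall within the usual scatter of compound 2 at 3100 nM. For compound 4 the estimated value is 4000 nM, with an expected range of 1500 nM to 10000 nM.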

Compound 4, half-maximal effective concentration: 2300 nM
The estimate for compound 4 lay 1.7-fold (0.24 log units) above the measured number; low and high end bracket the measured number.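

Within the data shown here, compound 3 has no number in this assay and compound 4 gives 2300 nM, so no step between them can be read. The compounds shown leave open how replacing the 2-fluoro-4-(methoxycarbamoyl)phenyl group alone affects this read-out.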